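Swapping the aryl ketone in a quinoline chalcone series

The source may report more compounds than this note shows. Statements on the series, on what has been measured and on what is new or still open speak of the compounds shown alone.

Three compounds that share one core and differ only in the aryl group on the carbonyl carbon have been measured in a functional assay on NCI-H1299 cells (Homo sapiens) for antiproliferative activity, read by XTT assay, with a stated time of 72 h; on this read-out higher numbers stand for weaker inhibition and lower numbers for stronger inhibition. Compound 1 `COc1ccc(-c2cc3ccccc3nc2/C=C/C(=O)c2ccc(OC)cc2OC)cc1` gives 3770 nM. Compound 2 `COc1ccc(-c2cc3ccccc3nc2/C=C/C(=O)c2ccc(OC)c(OC)c2)cc1` gives 1050 nM. Compound 3 `COc1ccc(-c2cc3ccccc3nc2/C=C/C(=O)c2cccs2)cc1` gives 720 nM, the lowest of the three numbers; its gap to compound 2 is within the scatter, while its gap to compound 1 is beyond it.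

Compound 4 `COc1ccc(-c2cc3ccccc3nc2/C=C/C(=O)c2ccccn2)cc1` differs from compound 3 in one place: pyridin-2-yl in place of thiophen-2-yl on a carbonyl carbon. For the measured compounds named here, two measured steps touch the same position. The step of a 5.2-fold lower number from compound 1 to compound 3 (0.72 log units; beyond the scatter) and the step of a 1.5-fold lower number from compound 2 to compound 3 (0.16 log units; within the scatter) both describe what happens when a dimethoxyphenyl group is exchanged for thiophen-2-yl, and only the first of them is beyond the scatter. Going by the values given here, no measured step exchanges one five-membered heteroaryl for a six-membered one, so the data give no direct guide to the step from compound 3 to compound 4. Given that compounds 2 and 3 sit within the scatter of each other despite quite different groups, a step of a 1.4-fold higher number from compound 3 to compound 4 (0.14 log units; within the scatter) is expected, likely not beyond the scatter or at most slightly upward. The estimate for compound 4 in this assay is 1000 nM, within a range from 400 nM to 2500 nM.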

Compound 4, half-maximal inhibitory concentration: 660 nM
For compound 4 the middle estimate is 1.5-fold (0.18 log units) above the measured one; measured number inside the range.
By their numbers in this assay, from the lowest: compounds 4, 3 and 2 (each within the scatter of the next); then compound 1.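

In this assay the carbonyl carbon now carries a six-membered aromatic ring as well as a five-membered one, and exchanging thiophen-2-yl for pyridin-2-yl gives a 1.1-fold lower number from compound 3 to compound 4 (0.04 log units; within the scatter) with no change that the numbers can support. The comparison with the 3,4-dimethoxyphenyl group gives a 1.6-fold lower number from compound 2 to compound 4 (0.20 log units; within the scatter) and is also unresolved, so pyridin-2-yl, thiophen-2-yl and 3,4-dimethoxyphenyl now form a set of three quite different groups that this read-out does not separate. The 2,4-dimethoxyphenyl group remains the only one of the four set apart, and a second heteroaryl ring confirms this with a 5.7-fold lower number from compound 1 to compound 4 (0.76 log units; beyond the scatter) as the step to pyridin-2-yl.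

The compounds shown leave open whether the place of the ring nitrogen matters, as pyridin-3-yl or pyridin-4-yl would show, and whether a plain phenyl or a cyclohexyl on the carbonyl carbon would stay with these three groups or part from them. No evidence is available to explain why these three groups read alike or why the 2,4-dimethoxyphenyl compound stands apart.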